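This account rests on a few compounds, and the source may have more. Where it says the series, first, only, none or still open, it means among the compounds named here.

Measured in an ADME assay on MT2 cells (Homo sapiens) for cytotoxicity, read by MTT assay; on this read-out lower numbers stand for higher toxicity in this test and higher numbers for lower toxicity in this test:
Compound 1, `Cc1cc(Oc2ccccc2OCCn2ccc(=O)[nH]c2=O)c2cc(C#N)[nH]c2c1`, gives 1200 nM.
Compound 2, `Cc1ccc2c(Oc3ccccc3OCCn3ccc(=O)[nH]c3=O)cccc2c1`, gives 40000 nM.
Compound 3, `N#Cc1cc2c(Oc3ccccc3OCCn3ccc(=O)[nH]c3=O)cccc2[nH]1`, gives 72000 nM.

Compound 3 holds the highest of the three numbers in this assay, though compound 2 lies within the usual scatter of it, while compound 1 sits far lower. The only single change measured among these compounds is a 60-fold higher number from compound 1 to compound 3 (1.78 log units; beyond the scatter), a large step in which a methyl group is replaced by hydrogen.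

Compound 4, `N#Cc1cc2c(Oc3ccccc3OCCn3ccc(=O)[nH]c3=O)cc(Cl)cc2[nH]1`, differs from compound 3 by chloro in place of hydrogen on an aromatic carbon. For the measured compounds named here, a chloro group appears in none of the measured compounds, so no measured step speaks directly to this change; the step from compound 1 to compound 3 concerns a different group and is at best a weak guide. With so little to go on, the expectation for compound 4 is a modest move toward a lower number, a 2.4-fold lower number from compound 3 to compound 4 (0.38 log units; beyond the scatter), carrying wide uncertainty. Compound 4 is therefore estimated at 30000 nM, within a range from 6000 nM to 120000 nM.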

Compound 4, half-maximal cytotoxic concentration: 81000 nM
Compound 4: middle estimate off by 2.7-fold (0.43 log units), on the low side; the range from low to high includes it.
By their numbers in this assay, from the lowest: compound 1; then compounds 2, 3 and 4 (each within the scatter of the next, the first and the last beyond it).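

Chloro and hydrogen on this aromatic carbon cannot be told apart in this assay (a 1.1-fold higher number from compound 3 to compound 4 (0.05 log units; within the scatter)). Chloro in place of methyl on the same carbon gives a large step (a 68-fold higher number from compound 1 to compound 4 (1.83 log units; beyond the scatter)), so among hydrogen, chloro and methyl, only methyl, in compound 1, goes with the low number, and adding a substituent at this place does not by itself bring that number down. Nothing available here gives a reason why methyl stands apart from chloro at this place.

On these data alone, it remains open whether the low number is particular to methyl or would also appear with an ethyl group, a methoxy group or an amine on this carbon. As far as these compounds go, it also remains open whether the same pattern would hold on a core without the nitrile.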